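Halogenated Benzyl Group in Place of Dimethoxy Pattern

The source may report more compounds than this note shows. Statements on the series, on what has been measured and on what is new or still open speak of the compounds shown alone.

Compound 1 `OC[C@H]1O[C@@H](n2cnc3c(NCc4cccc(F)c4)ncnc32)[C@H](O)[C@@H]1O` carries a 3-fluorophenyl group and in a functional assay on CCRF-CEM cells (Homo sapiens) for antiproliferative activity, with a stated time of 72 h (a lower number here means a stronger inhibitor, a higher number a weaker inhibitor), gives 4000 nM. Compound 2 `COc1cccc(CNc2ncnc3c2ncn3[C@@H]2O[C@H](CO)[C@@H](O)[C@H]2O)c1OC` carries a 2,3-dimethoxyphenyl group at the same place. In this assay compound 2 reaches only a limit, > 166000 nM, so it stands at the weak end of these numbers (the limit of > 166000 nM in this assay, at which 1 of the 2 values shown sits). That exchange cost an at least 41-fold higher number from compound 1 to compound 2 (1.61 log units; beyond the scatter). Compound 3 `OC[C@H]1O[C@@H](n2cnc3c(NCc4ccc(F)c(Cl)c4)ncnc32)[C@H](O)[C@@H]1O` differs from compound 2 in one place: 3-chloro-4-fluorophenyl in place of 2,3-dimethoxyphenyl on a saturated chain carbon bound to a nitrogen on an aromatic ring. Among the compounds with values here, the only measured step bearing on it is that large loss; returning to a halogenated phenyl is expected to reverse much of it, giving an at least 33-fold lower number from compound 2 to compound 3 (1.52 log units; beyond the scatter). Compound 3 is therefore estimated at 5000 nM, between 1500 nM and 40000 nM.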

Compound 3, half-maximal inhibitory concentration: 3400 nM
Estimate against measurement, compound 3: 1.5-fold (0.17 log units) above, and the stated range covers the measured number.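

In this assay, a halogenated phenyl group at this place restores activity lost with the 2,3-dimethoxyphenyl group, giving an at least 48-fold lower number from compound 2 to compound 3 (1.68 log units; beyond the scatter). The value for compound 2 is a limit, not a number: the limit of > 166000 nM in this assay, at which 1 of the 3 values shown sits. The 3-chloro-4-fluorophenyl and 3-fluorophenyl groups cannot be told apart here, with a 1.2-fold lower number from compound 1 to compound 3 (0.07 log units; within the scatter). Still open, as far as these compounds go, is whether the halogens themselves matter, or whether the dimethoxy pattern alone is the problem. From the compounds shown here alone, how a plain phenyl, or a ring carrying a single methoxy group or an amine, would behave on this chain carbon remains unknown.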